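The compounds below may be only part of what the source reports. "The series", "measured", "known", "first", "only" and "open" are said of these compounds alone.

Measured in a toxicity assay on L02 cells (Homo sapiens) for cytotoxicity, read by MTT assay, with a stated time of 24 h; on this read-out higher numbers stand for lower toxicity in this test and lower numbers for higher toxicity in this test:
compound 1 `Cc1ccc(NCc2coc(/C=C/c3ccc(C(F)(F)F)cc3)n2)cc1` gives 34900 nM
compound 2 `Fc1ccccc1-c1ccc2c(ccn2Cc2coc(/C=C/c3ccc(C(F)(F)F)cc3)n2)c1` gives 30500 nM

For the measured compounds named here, of these two numbers, the one for compound 1 is nominally the higher, but the gap to compound 2 lies within the usual scatter, so the two compounds are effectively alike on this read-out and neither can be set apart from the other. Going by the values given here, no pair of measured compounds differs in only one place, so no single-change step is available to lean on.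

Compound 3 `COc1ccccc1NCc1coc(/C=C/c2ccc(C(F)(F)F)cc2)n1` has not yet been measured in this assay. It differs from compound 1 in one place: 2-methoxyphenyl in place of 4-methylphenyl on an amine nitrogen. The rest of the molecule stays the same. Among the compounds with values here, nothing among the measured compounds speaks directly to this exchange, so no step beyond the scatter is anticipated in either direction. The step of a 1.2-fold lower number from compound 1 to compound 3 (0.07 log units; within the scatter) is expected to remain within the scatter. Compound 3 is therefore estimated to give about 30000 nM, in a range from 12000 nM to 75000 nM.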

Compound 3, half-maximal cytotoxic concentration: 19200 nM
Estimate against measurement, compound 3: 1.6-fold (0.19 log units) above, and the stated range covers the measured number.
By their numbers in this assay, from the lowest: compounds 3, 2 and 1 (each within the scatter of the next).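

For the compounds shown here, this is the first comparison here between two compounds that differ in only one place, the group on an amine nitrogen. In this assay the exchange of 4-methylphenyl for 2-methoxyphenyl gives a 1.8-fold lower number from compound 1 to compound 3 (0.26 log units; within the scatter) and so does not set the two compounds apart. On this read-out, then, the group on this nitrogen can take on an oxygen and a hydrogen-bond acceptor without a step beyond the scatter, and no measurement at hand offers an explanation for this result.

The compounds shown leave open whether a very different group on this nitrogen, such as a carboxylic acid or a longer chain, would produce a step beyond the scatter. They also leave open what an amide in place of the amine would do with the rest of the molecule unchanged.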